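A few compounds are considered here, and "the series" means these few. Any claim that something is new, unique, unknown or untested is made for them only; others in the source may bear on it.

Compound 2 `CCCNC(=O)CC1CCc2cc(OC)c(OC)cc21` stands highest of the two numbers measured in a functional assay on the whole organism (strain Wistar) for inhibition, with Rattus norvegicus as the target, read by paw edema, with stated times of 60 min and 6 h, at a dose of 100 mg/kg by the oral route (a higher number here means more inhibition at the dose given (going by the name of the read-out), a lower number less inhibition), where compound 2 gives 22.2%. Compound 1 `COc1cc2c(cc1OC)C(CC(=O)O)CC2` gives 20.4% in this assay, and the step of a number 1.8 percentage points higher from compound 1 to compound 2 (within the scatter) lies within the scatter, so the two compounds cannot be told apart on these numbers. Compound 3 `COc1cc2c(cc1OC)C(CC(=O)NC(C)C)CC2` has not yet been measured. It differs from compound 2 in one place: isopropyl in place of propyl on an amide-type nitrogen. Within the data shown here, the one measured step concerns a different change, hydroxy to propylamino on a carbonyl carbon, and was a number 1.8 percentage points higher from compound 1 to compound 2 (within the scatter); no measured step bears directly on exchanging a propyl for an isopropyl on an amide-type nitrogen. With nothing to point either way, compound 3 is expected to show no step beyond the scatter, an estimated a number 0.2 percentage points lower from compound 2 to compound 3 (within the scatter). Compound 3 is therefore estimated at 22%, in a range from 8% to 38%.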

Compound 3, a percentage reported as inhibition, in the whole organism at one dose (the size of the read-out at that dose, not a potency): 37%
The estimate for compound 3 lay 15 percentage points below the measured number, within the range that was stated.
By their numbers in this assay, from the lowest: compounds 1 and 2 (each within the scatter of the next); then compound 3.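

Among these compounds, on the amide-type nitrogen, how three carbons are joined makes a difference in this assay: isopropyl in place of propyl gives a number 14.8 percentage points higher from compound 2 to compound 3 (beyond the scatter) and is the first change here to go beyond the scatter. Set against the acid, isopropylamino in place of hydroxy on the carbonyl carbon gives a number 16.6 percentage points higher from compound 1 to compound 3 (beyond the scatter) while propylamino in that place gave only a number 1.8 percentage points higher from compound 1 to compound 2 (within the scatter) and so did not separate the two compounds. Nothing at hand explains why the isopropyl amide stands apart.

As far as these compounds go, whether a tert-butyl or cyclopropyl group on the same nitrogen would raise the inhibition further, or a longer chain such as butyl would lower it, remains open. From the compounds shown here alone, each number is also a single reading at one dose, so how the compounds compare in potency remains open too.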